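Allyloxy to propargyloxy on the shared core

The compounds below may be only part of what the source reports. "The series", "measured", "known", "first", "only" and "open" are said of these compounds alone.

Values in a functional assay on HCT-116 cells (Homo sapiens) for antiproliferative activity, read by MTT assay, with a stated time of 24 h (a higher number here means a weaker inhibitor, a lower number a stronger inhibitor), so far
- compound 1 `COc1cc(OC)c(-c2coc3cc(OCC=C(C)C)ccc3c2=O)cc1OC` gives 680 nM
- compound 2 `C=CCOc1ccc2c(=O)c(-c3cc(OC)c(OC)cc3OC)coc2c1` gives 6600 nM

Among the compounds with values here, compound 2 has the higher of the two numbers, which makes it the weaker inhibitor, and compound 1 is its only neighbour. The next compound, compound 3 `C#CCOc1ccc2c(=O)c(-c3cc(OC)c(OC)cc3OC)coc2c1`, differs from compound 2 at the chain end only ethynyl in place of vinyl on a saturated chain carbon bound to an oxygen on an aromatic ring and so carries propargyloxy in place of allyloxy. Within the data shown here, one measured step bears on this place, a 9.7-fold higher number from compound 1 to compound 2 (0.99 log units; beyond the scatter), with vinyl in place of 2-methylprop-1-en-1-yl. That step lies beyond the scatter, so changes at this chain end can register in this assay. It is a different exchange, however, and one that removes heavy atoms, whereas the present one does not change their count. Among the measured compounds shown here, no measured compound carries ethynyl, so no direction is supported. A much smaller step is expected, probably within the scatter. The expected step is a 1.1-fold lower number from compound 2 to compound 3 (0.04 log units; within the scatter). For compound 3 the estimated value is 6000 nM, with an expected range from 2000 nM to 20000 nM.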

Compound 3, half-maximal inhibitory concentration: 8050 nM
Compound 3: middle estimate off by 1.3-fold (0.13 log units), on the low side; the measured number falls inside the stated range.
By their numbers in this assay, from the lowest: compound 1; then compounds 2 and 3 (each within the scatter of the next).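

In this assay, ethynyl in place of vinyl on a saturated chain carbon bound to an oxygen on an aromatic ring gives a 1.2-fold higher number from compound 2 to compound 3 (0.09 log units; within the scatter) and so does not separate propargyloxy from allyloxy, at an exchange that leaves the heavy-atom count unchanged. Ethynyl in place of 2-methylprop-1-en-1-yl gives a 12-fold higher number from compound 1 to compound 3 (1.07 log units; beyond the scatter) and lies beyond the scatter, as does a 9.7-fold higher number from compound 1 to compound 2 (0.99 log units; beyond the scatter) in the same assay, so the gap to compound 1 is not confined to the vinyl end and appears with both of the smaller chain ends shown. No accompanying measurement accounts for either the gap or its absence between the vinyl and ethynyl ends.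

Among the compounds shown, 2-methylprop-1-en-1-yl is the only end that stands apart, so the branching of that end cannot be separated from its greater length. As far as these compounds go, how an unbranched longer chain, or an amine or a carboxylic acid at this chain end, would compare with compound 1 and with compound 2 remains open.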